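The source may hold more compounds than are shown below. What is called first, only, known or untested is meant among the compounds shown, and "the series" means these compounds.

The series holds three measured lactones and one awaiting measurement. Compound 2 `CCCCC[C@@H](CCC[C@H]1CC=CC(=O)O1)OC` in a functional assay on A2780 ADR cells (Homo sapiens) for cytotoxicity, read by MTT assay, with a stated time of 24 h (a lower number here means a stronger inhibitor, a higher number a weaker inhibitor), gives 9000 nM. Compound 1 `CCCCC[C@@H](C[C@H](O)C[C@@H]1CC=CC(=O)O1)OC` in this assay gives 26300 nM. Compound 3 `CCCCC[C@H](C[C@H](O)C[C@H]1CC=CC(=O)O1)OC` has the same atoms and bonds as compound 1, and in this assay compound 3 gives 57500 nM, the highest number of the three, standing above compound 1 and further still above compound 2. The step of a 2.2-fold higher number from compound 1 to compound 3 (0.34 log units; beyond the scatter) rests only on (the fact that compounds 1 and 3 differ only in the configuration as drawn).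

Within the data shown here, compound 4 `CCCCC[C@@H](C[C@@H](O)C[C@H]1CC=CC(=O)O1)OC` is the next isomer. the two compounds have the same atoms and bonds and differ only in configuration as drawn: 2 of 3 stereo elements differ; a stereocentre at a saturated chain carbon is drawn R in compound 3 and S in compound 4; a stereocentre at a saturated chain carbon is drawn S in compound 3 and R in compound 4 Only one measured step bears on such a change: a 2.2-fold higher number from compound 1 to compound 3 (0.34 log units; beyond the scatter), which also exchanged two stereo elements and moved the number only modestly, though beyond the scatter. Compound 4 keeps the ring stereocentre of compound 3 while returning one chain stereocentre to the drawing of compound 1, so the estimated step of a 1.6-fold lower number from compound 3 to compound 4 (0.22 log units; within the scatter) is expected to be small, most likely a slight lowering of the number back toward compound 1, with the sign not secure. Compound 4 is therefore estimated at 35000 nM, expected to lie between 12000 nM and 100000 nM.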

Compound 4, half-maximal inhibitory concentration: 25200 nM
Beside the measured number, compound 4's estimate is 1.4-fold (0.14 log units) above it; the measured number falls inside the stated range.
By their numbers in this assay, from the lowest: compound 2; then compounds 4 and 1 (each within the scatter of the next); then compound 3.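

The step of a 2.3-fold lower number from compound 3 to compound 4 (0.36 log units; beyond the scatter) shows that exchanging the two saturated chain stereocentres, with the ring stereocentre left as drawn, is enough on its own to move the number in this assay, something the earlier pair could not show because its exchange included the ring stereocentre: the fact that compounds 3 and 4 differ only in the configuration as drawn

An exchange at one chain stereocentre and the ring stereocentre has no single reading, for it gives a 1.0-fold lower number from compound 1 to compound 4 (0.02 log units; within the scatter) here, so that these two isomers cannot be told apart, yet it gave a 2.2-fold higher number from compound 1 to compound 3 (0.34 log units; beyond the scatter) in the earlier pair: the fact that compounds 1 and 4 differ only in the configuration as drawn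

The series also gains its first step for the hydroxy group itself, hydroxy in place of hydrogen on a saturated chain carbon bound to two saturated chain carbons, which reads a 2.8-fold higher number from compound 2 to compound 4 (0.45 log units; beyond the scatter).

On these data alone, that hydroxy step rests on this one pair, so it remains open whether the other hydroxy configurations would give the same step. As far as these compounds go, whether a ketone or an amine at that chain carbon, or a longer chain, would read nearer compound 2 or nearer compound 4 also remains open.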